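The source may hold more compounds than are shown below. What is called first, only, known or untested is meant among the compounds shown, and "the series" means these compounds.

Working notes on the shared core of compound 1 `CC1(C)N=C(N)N=C(N)N1c1cccc(OCCOc2ccc(S(=O)(=O)F)cc2)c1`, compound 2 `CC1(C)N=C(N)N=C(N)N1c1ccc(CCc2ccccc2)cc1` and compound 3 `CN(C)C(=O)c1cccc(NC(=O)NCc2cccc(N3C(N)=NC(N)=NC3(C)C)c2)c1`, all three tested in an assay on isolated protein for inhibition of Dihydrofolate reductase (Mus musculus); a lower number here means a less potent compound, a higher number a more potent compound, by a factor of ten per unit of this negative logarithm. Compound 1 gives 7.82 in this assay, compound 2 gives 7.89, and compound 3 gives 7.77. The number for compound 3 is the lowest of the three, but the gap to compound 1 and the gap to compound 2 both lie within the usual scatter, so the three numbers read as a single level rather than a ranking.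

The next step goes from compound 3 to compound 4 `CC1(C)N=C(N)N=C(N)N1c1cccc(CNC(=O)Nc2cccc(Cl)c2)c1`, which has not yet been measured in this assay. The change is chloro in place of dimethylcarbamoyl on an aromatic carbon, on an aromatic carbon of a six-membered aromatic ring of carbon only, meta to a large group. Within the data shown here, no step between measured compounds isolates such a change, so there is nothing in the present set that shows its effect directly. Given that the three measured compounds sit within the scatter of one another, the expected step from compound 3 to compound 4 in this assay is a number 0.07 log units lower from compound 3 to compound 4 (within the scatter), that is, none beyond the scatter. Compound 4 is therefore estimated at 7.7 in this assay, with a range from 7.1 to 8.3.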

Compound 4, logarithm of the reciprocal of the active concentration, log(1/C): 8.05
The estimate for compound 4 lay 0.35 log units below the measured number; the range from low to high includes it.
By their numbers in this assay, from the lowest: compounds 3, 1, 2 and 4 (each within the scatter of the next).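

Among the earlier compounds no pair differed in one place, so the effect of any single change stayed unseen; in this assay chloro in place of dimethylcarbamoyl on an aromatic carbon, meta to a large group, now gives a number 0.28 log units higher from compound 3 to compound 4 (within the scatter) and provides the first such reading for the series. At this position, a group of 5 heavy atoms with 1 hydrogen-bond acceptor and a double bond outside aromatic rings can give way to a chloro of 1 heavy atom with no hydrogen-bond acceptor, and the number stays within the scatter, so the dimethylcarbamoyl is not needed to hold this level of binding in this pair. No measurement at hand gives a reason for the step or for its size.

The compounds shown leave open what a carboxylic acid, a primary amine, a methoxy group or a longer alkyl chain would give at this position, and whether a ring with only hydrogen there would hold the same level. Going by these compounds, with a single pair as the basis, it also remains open whether the same exchange would give a similar step with a different chain joining this ring to the shared core.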